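A few compounds are considered here, and "the series" means these few. Any claim that something is new, unique, unknown or untested is made for them only; others in the source may bear on it.

Compound 1: `CC(=O)c1ccc2c(c1)nc(-c1ccc(Cl)cc1)n2C1CCCCC1`, > 100000 nM (a limit)
Compound 2: `C/C(=N\NC(N)=O)c1ccc2c(c1)nc(-c1ccc(Cl)cc1)n2C1CCCCC1`, > 100000 nM (a limit)
Compound 3: `C/C(=N\NC(N)=S)c1ccc2c(c1)nc(-c1ccccc1)n2C1CCCCC1`, 20000 nM

Among the measured compounds shown here, in an ADME assay on Vero cells (Chlorocebus sabaeus) for cytotoxicity, read by MTT assay, with a stated time of 96 h (a lower number here means that less compound is tolerated, a higher number that more compound is tolerated), compound 3 gives 20000 nM, the only exact number in this small set. All that is known of compound 1 and compound 2 is the limit of > 100000 nM in this assay, at which 2 of the 3 values shown sit.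

Compound 4, `C/C(=N\NC(N)=S)c1ccc2c(c1)nc(-c1ccc(Cl)cc1)n2C1CCCCC1`, differs from compound 3 by chloro in place of hydrogen on an aromatic carbon, which turns phenyl into 4-chlorophenyl: chloro in place of hydrogen on an aromatic carbon. For the measured compounds named here, the only measured step, a step that the two limits leave unreadable from compound 1 to compound 2, concerns a different change and gives no size. Going by the values given here, no measured step shows the new change, so no shift beyond the usual scatter is expected. The expected step is a 1.3-fold higher number from compound 3 to compound 4 (0.10 log units; within the scatter). For compound 4 the estimate is 25000 nM, with an expected range from 9000 nM to 70000 nM.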

Compound 4, half-maximal cytotoxic concentration: > 100000 nM
Compound 4: no number, only a limit; the forecaster's own chance of this, stated with the estimate: 15%; middle value at least 4.0-fold (0.60 log units) away from the limit.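

In this assay, among the compounds shown here, chloro in place of hydrogen on this aromatic carbon gives an at least 5.0-fold higher number from compound 3 to compound 4 (0.69 log units; beyond the scatter), the first readable step at this position. The value of compound 4 is a limit, shared with two other compounds: the limit of > 100000 nM in this assay, at which 3 of the 4 values shown sit.

The steps to compound 4 from compound 1 and compound 2 cannot be read. As far as these compounds go, whether another group in this place, such as methoxy or an amine, would also raise the number stays open. So does whether chloro would have the same effect with a different group on the shared core.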